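The source may hold more compounds than are shown below. What is called first, only, known or untested is meant among the compounds shown, and "the series" means these compounds.

Of the compounds shown here, three sharing one core have been measured in an assay for binding affinity to adenosine receptor A1 (Bos taurus); on this read-out lower numbers stand for stronger inhibition and higher numbers for weaker inhibition. Compound 1 `Cn1c(=O)c2nc(-c3ccc(Cl)cc3)[nH]c2n(C)c1=O` gives 0.8 nM, compound 2 `CN(C)c1ccc(-c2nc3c(=O)n(C)c(=O)n(C)c3[nH]2)cc1` gives 1.8 nM, and compound 3 `Cn1c(=O)c2nc(-c3ccc(I)cc3)[nH]c2n(C)c1=O` gives 1.3 nM. Among the compounds with values here, compound 3 thus sits among the others without a clear gap: there is a 1.6-fold higher number from compound 1 to compound 3 (0.21 log units; within the scatter) and a 1.4-fold lower number from compound 2 to compound 3 (0.14 log units; within the scatter), both within the scatter, while the only step beyond the scatter is a 2.3-fold higher number from compound 1 to compound 2 (0.35 log units; beyond the scatter).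

Compound 4 `CCc1ccc(-c2nc3c(=O)n(C)c(=O)n(C)c3[nH]2)cc1` is not yet measured. It differs from compound 3 by ethyl in place of iodo on an aromatic carbon. Within the data shown here, the steps that bear on this are those that swap the group at the same position: a 1.6-fold higher number from compound 1 to compound 3 (0.21 log units; within the scatter) and a 1.4-fold lower number from compound 2 to compound 3 (0.14 log units; within the scatter) were both within the scatter, and a 2.3-fold higher number from compound 1 to compound 2 (0.35 log units; beyond the scatter) was modest. Exchanges at this position have therefore shifted this assay little so far, though none of the measured exchanges introduced an ethyl. The step from compound 3 to compound 4 is accordingly expected to be small, a 1.5-fold higher number from compound 3 to compound 4 (0.19 log units; within the scatter), most likely within the scatter. On that basis compound 4 is estimated at 2 nM, with a likely range from 0.7 nM to 6 nM.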

Compound 4, half-maximal inhibitory concentration: 0.8 nM
Compound 4: the middle estimate sits 2.5-fold (0.40 log units) above what was measured, within the range that was stated.
By their numbers in this assay, from the lowest: compounds 1, 4, 3 and 2 (each within the scatter of the next, the first and the last beyond it).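

Ethyl is the first plain carbon chain at this position, and in this assay it cannot be told apart from the two halogens, with a 1.6-fold lower number from compound 3 to compound 4 (0.21 log units; within the scatter) and no change at the digits printed from compound 1 to compound 4 (within the scatter). Only against the dimethylamino group does the exchange pass the scatter, in a modest step, with a 2.3-fold lower number from compound 2 to compound 4 (0.35 log units; beyond the scatter). This position therefore takes chloro, iodo and ethyl alike, while compound 2 stands apart from compound 1 and compound 4 but not from compound 3.

No measured evidence is available to explain these small differences. On these data alone, whether a longer chain such as butyl, a carboxylic acid or a primary amine at this position would stay within the same narrow band of values remains open.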